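Butyl replaces 2-methoxyphenyl in a compound at the limit

The source may report more compounds than this note shows. Statements on the series, on what has been measured and on what is new or still open speak of the compounds shown alone.

Values in an ADME assay on HBZY-1 cells (Rattus norvegicus) for cytotoxicity, read by MTT assay, with a stated time of 2 h (a lower number here means a stronger inhibitor, a higher number a weaker inhibitor), follow, each one a limit:
Compound 1 (`COc1cc(NC(=O)/C=C/c2ccccc2C(F)(F)F)cc(OC)c1OC`): > 200000 nM
Compound 2 (`COc1ccc(CNC(=O)/C=C/c2ccccc2C(F)(F)F)cc1`): > 200000 nM
Compound 3 (`COc1ccccc1NC(=O)/C(C#N)=C/c1ccccc1C(F)(F)F`): > 200000 nM

Compound 3 stands at > 200000 nM in this assay as a limit, not a number. The picture so far is uniform (the limit of > 200000 nM in this assay, at which 3 of the 3 values shown sit). Compound 4 (`CCCCNC(=O)/C(C#N)=C/c1ccccc1C(F)(F)F`) carries butyl in place of 2-methoxyphenyl on an amide-type nitrogen. Among the compounds with values here, no measured pair gives a step to lean on. In this assay no step beyond the scatter is expected, in either direction. Compound 3 gives only a limit at > 200000 nM and no number to start from. The estimated step is small (a number no higher from compound 3 to compound 4 (the limit leaves the size open)). Compound 4 is expected near 200000 nM with an estimated range of 100000 nM to 400000 nM and may well turn out to be only a limit.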

Compound 4, half-maximal inhibitory concentration: > 200000 nM
Compound 4: a limit, no number; the forecaster's own chance of this, stated with the estimate: 85%; the middle value lies on the limit itself.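

Within the data shown here, compound 3 and compound 4 both give only a limit in this assay, so no step between them can be read. The compounds shown leave open whether swapping 2-methoxyphenyl for butyl changes cytotoxicity at all, and the values offer no number to compare: the limit of > 200000 nM in this assay, at which 4 of the 4 values shown sit.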